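The source may report more compounds than this note shows. Statements on the series, on what has been measured and on what is new or still open speak of the compounds shown alone.

Measured so far in an assay on isolated protein for inhibition of serine/threonine-protein kinase PLK2 (Homo sapiens), read by TR-FRET, with a stated time of 60 min; a higher number here means a weaker inhibitor, a lower number a stronger inhibitor:
Compound 1 `CC[C@@H]1C(=O)N(C)c2cnc(-n3ccnc3-c3ccc(F)cc3)nc2N1[C@H]1CCOC1` gives 33 nM.
Compound 2 `CC[C@@H]1C(=O)N(C)c2cnc(-n3ccnc3-c3ccccc3)nc2N1C1CCCC1` gives 5 nM.
Compound 3 `CC[C@@H]1C(=O)N(C)c2cnc(-n3ccnc3-c3ccc(F)cc3)nc2N1CCC(F)(F)F` gives 42 nM.

Among these three, compound 2 has the lowest number in this assay, and both gaps to the others are beyond the scatter, so compound 2 is the strongest inhibitor shown here. Compound 4 `CC[C@@H]1C(=O)N(C)c2cnc(-n3ccnc3-c3ccccc3)nc2N1[C@H]1CCOC1` is the next compound to be measured. It shares the core of compound 2 and differs in one place: oxolan-3-yl in place of cyclopentyl on a nitrogen on an aromatic ring in a ring.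

For the measured compounds named here, only one measured step is available, and it concerns a different swap on the same nitrogen: a 1.3-fold higher number from compound 1 to compound 3 (0.10 log units; within the scatter). It shows that exchanging one group for another at this position can leave the number essentially unchanged, but it does not involve cyclopentyl, so it bears on the present change only indirectly. Compounds 1 and 2 differ both at this nitrogen and on the phenyl ring, so their values alone cannot separate the two changes; they show only that the combined difference is beyond the scatter. Going by the values given here, with no direct precedent, the expected step of a 3.0-fold higher number from compound 2 to compound 4 (0.48 log units; beyond the scatter) is modest, most likely a somewhat higher number, with a fair chance it stays within the scatter. Compound 4 is therefore estimated at 15 nM in this assay, in a range from 5 nM to 45 nM.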

Compound 4, half-maximal inhibitory concentration: 8 nM
For compound 4 the middle estimate is 1.9-fold (0.27 log units) above the measured one, within the range that was stated.
By their numbers in this assay, from the lowest: compounds 2 and 4 (each within the scatter of the next); then compounds 1 and 3 (each within the scatter of the next).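

In this assay, the swap on this nitrogen gives a 1.6-fold higher number from compound 2 to compound 4 (0.20 log units; within the scatter), so a five-membered ring with one oxygen and one hydrogen-bond acceptor can replace the all-carbon ring with no change that stands out from the scatter. For the compounds shown here, with oxolan-3-yl kept on the nitrogen, hydrogen in place of fluoro on an aromatic carbon gives a 4.1-fold lower number from compound 1 to compound 4 (0.62 log units; beyond the scatter), the first single change in this set that lies beyond the scatter, whereas both swaps on the nitrogen lie within it. The data shown offer no explanation for either step.

On these data alone, the groups on this nitrogen cover only cyclopentyl, oxolan-3-yl and 3,3,3-trifluoropropyl, so it remains open how a ring carrying an amine, such as piperidin-4-yl, or a carboxylic acid would behave there. As far as these compounds go, it is also open whether the effect of removing fluoro would be the same with cyclopentyl on the nitrogen, and how chloro or methoxy on the same aromatic carbon would compare.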